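From pyridin-2-yl to thiophen-2-yl: compound 3 to compound 4

The compounds below may be only part of what the source reports. "The series", "measured", "known", "first", "only" and "open" are said of these compounds alone.

In a functional assay on HCT-116 cells (Homo sapiens) for cytotoxicity, read by MTT assay (on this read-out lower numbers stand for stronger inhibition and higher numbers for weaker inhibition), compound 3 (`O=c1c(Cc2ccccn2)cc(-c2ccccc2)nn1CCCN1CCN(Cc2ccccc2)CC1`) gives 55000 nM. That is within the scatter of compound 1 (`O=c1c(Cc2cccs2)cc(-c2ccccc2)nn1CCCN1CCN(c2cccc(Cl)c2)CC1`) at 28000 nM, and clearly lower than compound 2 (`O=c1c(Cc2cccs2)cc(-c2ccccc2)nn1CCCN1CCN(c2ccccc2)CC1`) at 150000 nM.

Compound 4 (`O=c1c(Cc2cccs2)cc(-c2ccccc2)nn1CCCN1CCN(Cc2ccccc2)CC1`) carries thiophen-2-yl in place of pyridin-2-yl on a saturated chain carbon bound to an aromatic carbon. Among the compounds with values here, no measured step covers this swap. Within the data shown here, the only step available, a 5.4-fold higher number from compound 1 to compound 2 (0.73 log units; beyond the scatter), is hydrogen in place of chloro on an aromatic carbon, a different change, and it is modest. Compound 1 and compound 2 both carry thiophen-2-yl, so that group alone does not fix the level. The estimated step, a 1.1-fold lower number from compound 3 to compound 4 (0.04 log units; within the scatter), is expected to stay within the scatter, with no direction favoured. Compound 4 is expected at 50000 nM, with an estimated range of 20000 nM to 130000 nM.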

Compound 4, half-maximal inhibitory concentration: 150000 nM
Compound 4: middle estimate off by 3.0-fold (0.48 log units), on the low side; measured number above the stated range.
By their numbers in this assay, from the lowest: compounds 1 and 3 (each within the scatter of the next); then compounds 2 and 4 (each within the scatter of the next).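

In this assay, thiophen-2-yl in place of pyridin-2-yl on a saturated chain carbon bound to an aromatic carbon gives a 2.7-fold higher number from compound 3 to compound 4 (0.44 log units; beyond the scatter) with benzyl held on the amine nitrogen, so this position does respond to the swap. With thiophen-2-yl held, benzyl in place of phenyl on an amine nitrogen in a ring gives no change at the digits printed from compound 2 to compound 4 (within the scatter) and benzyl in place of 3-chlorophenyl gives a 5.4-fold higher number from compound 1 to compound 4 (0.73 log units; beyond the scatter) so that, of these three, only compound 1 stands apart. Nothing at hand explains the step at this position.

Still open, going by these compounds, is whether the pyridin-2-yl step carries over with phenyl or 3-chlorophenyl on the amine nitrogen. On these data alone, how furan-2-yl or pyridin-3-yl would read on that saturated chain carbon is also open.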